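The source may report more compounds than this note shows. Statements on the series, on what has been measured and on what is new or still open speak of the compounds shown alone.

Measured so far in an ADME assay on Vero cells (Chlorocebus sabaeus) for cytotoxicity, read by resazurin assay, with a stated time of 69 h; a lower number here means that less compound is tolerated, a higher number that more compound is tolerated:
- compound 1 `O=C(O)CCNC(=O)c1cccc(C(=O)NCCC(=O)O)n1` gives > 100000 nM, which is a limit of the assay.
- compound 2 `O=C(O)CCNC(=O)c1cc(-c2cccc3ccccc23)cc(C(=O)NCCC(=O)O)n1` gives > 100000 nM, a limit.
- compound 3 `O=C(CCNC(=O)c1cc(-c2cccc3ccccc23)cc(C(=O)NCCC(=O)NO)n1)NO` gives > 100000 nM, a limit.

Compound 2 to compound 1 carries hydrogen in place of naphthalen-1-yl on an aromatic carbon, and the step that the two limits leave unreadable from compound 2 to compound 1 is one that the two limits leave unreadable. The difference between the core of compound 2 and the core of compound 3 is not broken down here.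

Compound 4 `O=C(CCNC(=O)c1cccc(C(=O)NCCC(=O)NO)n1)NO`, not yet measured in this assay, differs from compound 3 by hydrogen in place of naphthalen-1-yl on an aromatic carbon. This is the same kind of change as from compound 2 to compound 1; around the place the groups differ, meta to two (2-(hydroxycarbamoyl)ethyl)carbamoyl groups rather than meta to two (2-carboxyethyl)carbamoyl groups.

Given (the limit of > 100000 nM in this assay, at which 3 of the 3 values shown sit), the step that the limit leaves unreadable from compound 3 to compound 4 is expected to be flat. Compound 4 is estimated at 150000 nM, most likely reported as a limit again.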

Compound 4, half-maximal cytotoxic concentration: > 100000 nM
Compound 4: a limit, no number (the forecaster's own chance of this, stated with the estimate: 85%); the middle value does not contradict the limit.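

No step can be read between compound 3 and compound 4, as both stand at a limit: the limit of > 100000 nM in this assay, at which 4 of the 4 values shown sit.

The compounds shown leave open what concentration of any of them reaches the half-maximal cytotoxic level in this assay, and whether naphthalen-1-yl changes it.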